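A few compounds are considered here, and "the series" means these few. Any claim that something is new, unique, unknown or untested is made for them only; others in the source may bear on it.

Within the data shown here, compound 1 `COc1cccc(CNCCCNc2ccnc3cc(Oc4ccc(Cl)cc4)ccc23)c1O` is one of two compounds measured so far in an ADME assay on HepG2 cells (Homo sapiens) for cytotoxicity, read by luminescence, CellTiter-Glo and ATP content, with a stated time of 72 h; a higher number here means that more compound is needed for the effect, a lower number that less compound is needed. In this assay compound 1 gives 5700 nM, the higher of the two numbers. Compound 2 `COc1ccc(F)cc1CNCCCNc1ccnc2cc(CCC(C)C)ccc12`, which shares the core but carries different groups at both ends, gives 890 nM, a gap that lies beyond the scatter of repeated measurements, so compound 1 needs more compound for the same effect than compound 2.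

Compound 3 `COc1cccc(CNCCCNc2ccnc3cc(-c4ccc(C(F)(F)F)cc4)ccc23)c1O` has not yet been measured. It differs from compound 1 in one place: 4-(trifluoromethyl)phenyl in place of 4-chlorophenoxy on an aromatic carbon. Among the measured compounds shown here, no step between two measured compounds isolates this change, so any expectation rests on the two numbers alone and on the size of the group that enters.

For compound 3 a modest move toward a lower number, beyond the scatter but not large, is expected, a 2.3-fold lower number from compound 1 to compound 3 (0.36 log units; beyond the scatter). Compound 3 is therefore estimated at 2500 nM, with a range from 800 nM to 8000 nM.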

Compound 3, half-maximal effective concentration: 2210 nM
Estimate against measurement, compound 3: 1.1-fold (0.05 log units) above, and the stated range covers the measured number.
By their numbers in this assay, from the lowest: compound 2; then compound 3; then compound 1.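

In this assay the first pair differing in one place gives a 2.6-fold lower number from compound 1 to compound 3 (0.41 log units; beyond the scatter), with 4-(trifluoromethyl)phenyl in place of 4-chlorophenoxy. The group that enters keeps the six-membered aromatic ring of carbon only but has neither the oxygen nor the chlorine of the group that leaves, and this position takes the exchange with a step of modest size. Nothing measured here accounts for the direction or size of this step.

The exchange alters the link to the ring and the group on that ring together, so the compounds shown cannot separate the two. Also open, from the compounds shown here alone, is how the number would respond at this position to a directly attached 4-chlorophenyl, a 4-(trifluoromethyl)phenoxy, an amine or a carboxylic acid.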